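Shortening the Chain on the Weaker Diastereomer

This account rests on a few compounds, and the source may have more. Where it says the series, first, only, none or still open, it means among the compounds named here.

Compound 1 `CCCCSc1nsnc1[C@H]1CN2CCC[C@H]1C2` was tested in a functional assay on the whole organism for inhibition, with Rattus norvegicus as the target; on this read-out lower numbers stand for an effect already at smaller amounts and higher numbers for an effect only at larger amounts of compound. For compound 1 this assay reports only a limit, > 3 mg/kg. Its diastereomer, compound 2 `CCCCSc1nsnc1[C@H]1CN2CCC[C@@H]1C2`, gives 0.017 mg/kg in this assay. Among the measured compounds shown here, the only measured step, an at least 170-fold lower number from compound 1 to compound 2 (2.24 log units; beyond the scatter), is a large one, and it goes with the fact that one of compounds 1 and 2 is drawn with a defined configuration and the other without, at the place where they differ and with the limit of > 3 mg/kg in this assay, at which 1 of the 2 values shown sits, rather than with any change in the chain.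

Compound 3 `CCCSc1nsnc1[C@H]1CN2CCC[C@H]1C2` differs from compound 1 by hydrogen in place of methyl on a saturated chain carbon, three bonds along the chain from a sulfur. For the measured compounds named here, no measured pair changes the chain, so the measured steps give no guide to the size or direction of this change in this assay. With compound 1 known only as a limit, the expected step that the limit leaves unreadable from compound 1 to compound 3 is none beyond the scatter. Compound 3 is therefore estimated at 5 mg/kg, within a range from 1 mg/kg to 30 mg/kg, and most probably this assay will again report only a limit for it.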

Compound 3, dose for half-maximal effect: > 3 mg/kg
Compound 3 ended at the assay's limit; the forecaster's own chance of this, stated with the estimate: 75%; the middle value is on the limit's open side.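

Among the compounds shown here, compound 1 and compound 3 both stand only at a limit in this assay, so no step between them can be read. The compounds shown leave open what the change from butyl to propyl does in this assay, on either diastereomer.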